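A few compounds are considered here, and "the series" means these few. Any claim that something is new, unique, unknown or untested is made for them only; others in the source may bear on it.

Compound 1, `Nc1ncnc2c1ncn2CC(O)C(=O)OCCO`, bears a 2-hydroxyethyl ester on the shared core. In a functional assay on PRK cells (Oryctolagus cuniculus) for cytotoxicity (on this read-out lower numbers stand for higher toxicity in this test and higher numbers for lower toxicity in this test), compound 1 gives only a limit, > 400 ug/mL, and not a number. Compound 2, `COC(=O)C(O)Cn1cnc2c(N)ncnc21`, likewise reaches only a limit, > 400 ug/mL. Compound 3, `CCCOC(=O)C(O)Cn1cnc2c(N)ncnc21`, gives 100 ug/mL. The step from compound 1 to compound 4, `Nc1ncnc2c1ncn2CC(O)C(=O)OCc1ccco1`, is furan-2-yl in place of hydroxymethyl on a saturated chain carbon bound to an oxygen next to a carbonyl group. For the measured compounds named here, two measured steps bear on it: an at least 4.0-fold lower number from compound 1 to compound 3 (0.60 log units; beyond the scatter) and an at least 4.0-fold lower number from compound 2 to compound 3 (0.60 log units; beyond the scatter), both of which replace a polar or small group on the ester chain with a larger hydrocarbon and give a lower number; compound 4 carries a larger aromatic ester group in the same place. A number below the limit is therefore expected for compound 4, with an at least 4.0-fold lower number from compound 1 to compound 4 (0.60 log units; beyond the scatter), and its value in this assay is estimated at 100 ug/mL, between 25 ug/mL and 400 ug/mL.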

Compound 4, minimum cytotoxic concentration: 40 ug/mL
Compound 4: the middle estimate sits 2.5-fold (0.40 log units) above what was measured; measured number inside the range.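

At this place on the ester chain, furan-2-yl takes the number further down than ethyl, with a 2.5-fold lower number from compound 3 to compound 4 (0.40 log units; beyond the scatter) in this assay. The gaps to the two compounds that reach only a limit are wider, with an at least 10-fold lower number from compound 1 to compound 4 (1.00 log units; beyond the scatter) and an at least 10-fold lower number from compound 2 to compound 4 (1.00 log units; beyond the scatter), but these sizes are bounds and not exact values: the limit of > 400 ug/mL in this assay, at which 2 of the 4 values shown sit.

As far as these compounds go, whether a phenyl ring, an amine or a longer chain in this place would give a lower or a higher number than furan-2-yl stays open. From the compounds shown here alone, it is also open whether the aromatic ring itself matters, or only the size of the group.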